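Moving the Ring Nitrogen on a Shared Core

This account rests on a few compounds, and the source may have more. Where it says the series, first, only, none or still open, it means among the compounds named here.

Compound 2 `Oc1cccc(-c2cc(-c3ccccn3)cc(-c3cccc(O)c3)n2)c1` carries a pyridin-2-yl group on an aromatic carbon of its core, opposite the ring nitrogen and meta to two 3-hydroxyphenyl groups. Among the compounds with values here, in an assay on isolated protein for inhibition of DNA topoisomerase 1 (Homo sapiens), with a stated time of 30 min, tested at 100 uM (a lower number here means a weaker effect, a higher number a stronger effect of the compound at the concentration tested), compound 2 gives 8.3%, the lowest of the two numbers measured so far. Compound 1 `Oc1cccc(-c2cc(-c3ccsc3)cc(-c3cccc(O)c3)n2)c1` differs from it only by a thiophen-3-yl group at that place, and in this assay compound 1 gives 59.2%. Within the data shown here, the single measured step, a number 50.9 percentage points lower from compound 1 to compound 2 (beyond the scatter), shows how strongly this position answers to the choice of aromatic group. Compound 3 `Oc1cccc(-c2cc(-c3cccnc3)cc(-c3cccc(O)c3)n2)c1` is the next variation: pyridin-3-yl in place of pyridin-2-yl on an aromatic carbon. Among the measured compounds shown here, no measured step moves the nitrogen within a pyridyl group, so the step from compound 1 to compound 2 says only that a change at this place can be large, not which way this one goes. Because compound 2 already sits at the weak end with 8.3%, there is more room upward than downward, and compound 3 is therefore expected to give 25%, within 5% to 55%, an expected step of a number 16.7 percentage points higher from compound 2 to compound 3 (beyond the scatter).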

Compound 3, a percentage reported as inhibition, at one concentration (the size of the read-out at that concentration, not a potency): 2.1%
For compound 3 the middle estimate is 22.9 percentage points above the measured one; the whole stated range lies above it.
By their numbers in this assay, from the lowest: compounds 3 and 2 (each within the scatter of the next); then compound 1.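

In this assay, within the data shown here, the change from pyridin-2-yl to pyridin-3-yl is the first measured move of the nitrogen within a pyridyl group, and it comes to a number 6.2 percentage points lower from compound 2 to compound 3 (within the scatter), so the two pyridyl groups cannot be told apart in this assay. Putting pyridin-3-yl in place of thiophen-3-yl gives a number 57.1 percentage points lower from compound 1 to compound 3 (beyond the scatter), a large step like the one already seen for pyridin-2-yl, so among these three compounds the clear gap lies between thiophen-3-yl and both pyridyl groups, not between the two pyridyl groups. No measurement is available that would explain this gap.

The compounds shown leave open whether pyridin-4-yl would stay with the other two pyridyl groups at the low end or whether some placement of the nitrogen could restore the higher number seen with thiophen-3-yl. They also leave open whether the sulfur-containing ring itself matters, which thiophen-2-yl, furan-3-yl or a plain phenyl group at the same place on the shared core would begin to test.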